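The compounds below may be only part of what the source reports. "The series", "measured", "known", "first", "only" and "open" are said of these compounds alone.

Compound 1, `COc1cc2ncnc(NNC(=S)NC(=O)c3ccc(C(F)(F)F)cc3)c2cc1OC`, gives 9280 nM in a functional assay on MGC-803 cells (Homo sapiens) for cytotoxicity, read by MTT assay, with a stated time of 72 h; on this read-out lower numbers stand for stronger inhibition and higher numbers for weaker inhibition. Compound 2, `COc1cc2ncnc(NNC(=S)NC(=O)c3ccc(F)cc3)c2cc1OC`, gives 8300 nM. Compound 3, `O=C(NC(=S)NNc1ncnc2ccccc12)c1cccc(Cl)c1`, gives 4540 nM.

Compound 3 gives the lowest of the three numbers, yet its gap to compound 2 is within the scatter; only the gap to compound 1 lies beyond it. The step to compound 4, `O=C(NC(=S)NNc1ncnc2ccccc12)c1ccc(Cl)cc1`, is 4-chlorophenyl in place of 3-chlorophenyl on a carbonyl carbon. Within the data shown here, no measured step changes the position of a substituent on that ring. Among the measured compounds shown here, the one measured step, a 1.1-fold lower number from compound 1 to compound 2 (0.05 log units; within the scatter), swaps one group for another on a different core and stays within the scatter, so it offers little guidance here. With nothing pointing either way, compound 4 is expected to give a number close to that of compound 3, a step of a 1.0-fold lower number from compound 3 to compound 4 (0.00 log units; within the scatter), estimated at 4500 nM, in the range 2000 nM to 10000 nM.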

Compound 4, half-maximal inhibitory concentration: 1860 nM
Compound 4: the middle estimate sits 2.4-fold (0.38 log units) above what was measured; measured number outside the range, below it.
By their numbers in this assay, from the lowest: compound 4; then compounds 3, 2 and 1 (each within the scatter of the next, the first and the last beyond it).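

In this assay, 4-chlorophenyl in place of 3-chlorophenyl on the carbonyl carbon gives a 2.4-fold lower number from compound 3 to compound 4 (0.39 log units; beyond the scatter), so with the same atoms joined differently, the place of the chlorine on this ring alone shifts the number beyond the scatter. Among these compounds, the only earlier step, between compound 1 and compound 2, exchanged one group for another and stayed within the scatter. Nothing measured here bears on why the number moves.

From the compounds shown here alone, whether a methoxy group or an amine in place of the chlorine would give a lower number than compound 4 stays open. So does whether this step would hold on the core of compound 1.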